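The source may hold more compounds than are shown below. What is called first, only, known or untested is meant among the compounds shown, and "the series" means these compounds.

Values in a functional assay on MCF7 cells (Homo sapiens) for inhibition, read by CCK-8 assay, with a stated time of 48 h; a higher number here means a weaker inhibitor of growth, a lower number a stronger inhibitor of growth:
compound 1 `Cc1ccccc1Nc1nc(Nc2ccccc2)ncc1Cl`: > 100000 nM (a limit of the assay)
compound 2 `Cc1ccccc1Nc1nc(Nc2ccc(N3CCN(C)CC3)cc2)ncc1Cl`: 20600 nM
compound 3 `CCN1CCN(c2ccc(Nc3ncc(Cl)c(Nc4ccccc4C)n3)cc2)CC1`: 3160 nM

Compound 3 has the lowest of the two actual numbers, and compound 2 is its nearest neighbour.

Next comes compound 4 `Cc1ccccc1Nc1nc(Nc2ccc(N3CCN(C(=O)OC(C)(C)C)CC3)cc2)ncc1Cl`, which has tert-butoxycarbonyl in place of ethyl on an amine nitrogen in a ring.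

The closest measured change is at this same group, and it is modest: a 6.5-fold lower number from compound 2 to compound 3 (0.81 log units; beyond the scatter). The two larger steps show what adding the substituted ring did: an at least 4.8-fold lower number from compound 1 to compound 2 (0.68 log units; beyond the scatter) and an at least 31-fold lower number from compound 1 to compound 3 (1.50 log units; beyond the scatter). Compound 4 keeps that ring, so a return to the limit seen for compound 1 is not the main expectation. Among the compounds with values here, no measured compound carries tert-butoxycarbonyl, so the size of this step remains uncertain. Given a 6.5-fold lower number from compound 2 to compound 3 (0.81 log units; beyond the scatter), the group clearly matters, and a modest move to a higher number is expected in this assay. The expected change is a 2.8-fold higher number from compound 3 to compound 4 (0.45 log units; beyond the scatter). For compound 4 the estimated value is 9000 nM, with an expected range of 1800 nM to 45000 nM.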

Compound 4, concentration for 50% growth inhibition: 2250 nM
Compound 4: the middle estimate sits 4.0-fold (0.60 log units) above what was measured; low and high end bracket the measured number.
By their numbers in this assay, from the lowest: compounds 4 and 3 (each within the scatter of the next); then compound 2. At a limit, above all of these: compound 1.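

At the amine nitrogen in the ring, ethyl and tert-butoxycarbonyl cannot be separated in this assay: the exchange gives a 1.4-fold lower number from compound 3 to compound 4 (0.15 log units; within the scatter). The earlier compounds shown here covered only methyl and ethyl here, whereas this position also accommodates a group of 7 heavy atoms with a carbonyl, with no cost in this assay. Against methyl, the same group gives a 9.2-fold lower number from compound 2 to compound 4 (0.96 log units; beyond the scatter), so among the substituents on this nitrogen, methyl alone stands apart from the other two.

Open, going by these compounds, is whether a longer chain such as propyl, an acetyl group or the free ring amine would group with compound 3 and compound 4 or with compound 2. Nothing in the data explains why ethyl and tert-butoxycarbonyl give such similar numbers.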